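This account rests on a few compounds, and the source may have more. Where it says the series, first, only, none or still open, it means among the compounds named here.

Of the compounds shown here, three have been measured in a functional assay on SNB-19 cells (Homo sapiens) for cytotoxicity, read by sulforhodamine B assay, with a stated time of 48 h, tested at 10 uM; a higher number here means a weaker effect of the compound at the concentration tested, a lower number a stronger effect. Compound 1 `COc1cc(-c2cc(/C=C/C(=O)c3ccc(Cl)c(Cl)c3)[nH]n2)cc(OC)c1OC` gives 50%, the highest of the three numbers. Compound 2 `COc1ccc(-c2cc(/C=C/C(=O)c3ccc(N)cc3)[nH]n2)cc1` gives 5% in this assay, a number that lies beyond the scatter below compound 1, and compound 3 `COc1cc(C(=O)/C=C/c2cc(-c3cc(OC)c(OC)c(OC)c3)n[nH]2)cc(OC)c1OC` gives -62% in this assay, the furthest below compound 1 and likewise beyond the scatter. Compound 4 `COc1cc(-c2cc(/C=C/C(=O)c3ccc(F)c(F)c3)[nH]n2)cc(OC)c1OC` has not been measured. It differs from compound 1 in one place: 3,4-difluorophenyl in place of 3,4-dichlorophenyl on a carbonyl carbon. For the measured compounds named here, no measured pair shows the same change, so the data give no step for it. The step of a number 8 percentage points higher from compound 1 to compound 4 (within the scatter) is therefore expected to be none beyond the scatter. The estimate for compound 4 is 58%, in the range 20% to 95%.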

Compound 4, a percentage reported as activity, at one concentration (the size of the read-out at that concentration, not a potency): 25%
Beside the measured number, compound 4's estimate is 33 percentage points above it; the measured number falls inside the stated range.
By their numbers in this assay, from the lowest: compound 3; then compound 2; then compound 4; then compound 1.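

In this assay, the place on the carbonyl carbon proves sensitive to which halogens its phenyl ring carries: 3,4-difluorophenyl in place of 3,4-dichlorophenyl gives a number 25 percentage points lower from compound 1 to compound 4 (beyond the scatter), a shift towards the stronger effect. This is the first one-place comparison among these compounds, which until now offered no step at all. Nothing at hand explains the step.

The compounds shown leave open how a plain phenyl or a phenyl carrying two methyl groups would behave at this place. They also leave open whether the same exchange gives a similar step on another core.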